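Cyano for methyl on a benzyl group in compound 4

The source may report more compounds than this note shows. Statements on the series, on what has been measured and on what is new or still open speak of the compounds shown alone.

Measured compounds:
compound 1 `C[C@@H](c1ccccc1)n1cnc2c(N(C)C)ncnc21` 33%
compound 2 `CN(c1ncnc2c1ncn2Cc1ccccc1)C1CCCC1` 17%
compound 3 `Cc1ccc(Cn2cnc3c(N(C)C)ncnc32)cc1` 0%

In a functional assay on the whole organism for inhibition, with Rattus norvegicus as the target, in the maximal electroshock model, at a dose of 25 mg/kg by the intraperitoneal route (a higher number here means more inhibition at the dose given (going by the name of the read-out), a lower number less inhibition), compound 1 gives 33% and compound 2 gives 17%. Compound 3 stands lowest of the three in this assay with 0%; its gap to compound 2 and its gap to compound 1 both lie beyond the scatter. Compound 4 `CN(C)c1ncnc2c1ncn2Cc1ccc(C#N)cc1` is not yet measured. It differs from compound 3 in one place: cyano in place of methyl on an aromatic carbon. For the measured compounds named here, no step between measured compounds separates a methyl from a cyano here, so the data give no direct guide to the size of this change. A small step is expected, the estimated step of a number 10 percentage points higher from compound 3 to compound 4 (within the scatter) staying within the scatter. Compound 4 is expected to give 10% in this assay, with a range from 0% to 35%.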

Compound 4, a percentage reported as inhibition, in the whole organism at one dose (the size of the read-out at that dose, not a potency): 0%
For compound 4 the middle estimate is 10 percentage points above the measured one; measured number inside the range.
By their numbers in this assay, from the lowest: compounds 3 and 4 (each within the scatter of the next); then compound 2; then compound 1.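

In this assay, cyano in place of methyl on the aromatic carbon para to a large group gives no change at the digits printed from compound 3 to compound 4 (within the scatter), the first step measured at this position. Compound 3 reads 0% and compound 4 reads 0%, so neither group gives any inhibition at this dose, and this step cannot show how far a group here can move the number. On these data alone, it remains open whether an amine, a methoxy group or a carboxylic acid on this carbon would give a number above these. Nothing measured here accounts for this result.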